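Acetyl in place of methyl on the side-chain oxygen

The source may hold more compounds than are shown below. What is called first, only, known or untested is meant among the compounds shown, and "the series" means these compounds.

Within the data shown here, compound 2 `COCC[S+]([O-])CC1CN(C)CCC1c1ccc(Cl)cc1` gives 15 nM in an assay on isolated protein for inhibition of sodium-dependent dopamine transporter (Rattus norvegicus), read by radioligand binding; on this read-out higher numbers stand for weaker inhibition and lower numbers for stronger inhibition; it is one of only two numbers so far, the other belonging to compound 1 `CN1CCC(c2ccc(Cl)cc2)C(C[S+]([O-])CCO)C1`, which gives 12 nM in this assay, and the step of a 1.3-fold higher number from compound 1 to compound 2 (0.10 log units; within the scatter) lies within the scatter. Compound 3 `CC(=O)OCC[S+]([O-])CC1CN(C)CCC1c1ccc(Cl)cc1` is not yet measured; it differs from compound 2 by acetyl in place of methyl on an oxygen on a saturated carbon. Among the measured compounds shown here, the only measured step at this oxygen is a 1.3-fold higher number from compound 1 to compound 2 (0.10 log units; within the scatter), hydrogen to methyl, and it did not move the number beyond the scatter. Acetyl in place of methyl at the same oxygen is a larger change than that one, and the series holds no precedent for it, so no direction can be read from the data; the expectation is that the step of a 1.3-fold higher number from compound 2 to compound 3 (0.12 log units; within the scatter) stays within the scatter. Compound 3 is therefore estimated at 20 nM in this assay, with a range of 7 nM to 60 nM.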

Compound 3, inhibition constant: 9 nM
Beside the measured number, compound 3's estimate is 2.2-fold (0.35 log units) above it; the range from low to high includes it.
By their numbers in this assay, from the lowest: compounds 3, 1 and 2 (each within the scatter of the next).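

In this assay, the side-chain oxygen now carries hydrogen, methyl or acetyl, and both new steps, a 1.7-fold lower number from compound 2 to compound 3 (0.22 log units; within the scatter) and a 1.3-fold lower number from compound 1 to compound 3 (0.12 log units; within the scatter), stay within the scatter. The change from 2-methoxyethyl to 2-acetoxyethyl is larger than hydrogen to methyl, yet it does not move the number beyond the scatter, so these three compounds give no order at this oxygen and show that an acetyl here is accommodated as well as the smaller groups. No measured evidence bears on this result.

From the compounds shown here alone, whether a benzoyl in place of acetyl on this oxygen would leave the number within the scatter remains open. So does the effect of replacing the oxygen substituent with an amine or a carboxylic acid, or of a longer chain between the oxygen and the rest of the molecule.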